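Ester Group Variation on a Shared Core

A few compounds are considered here, and "the series" means these few. Any claim that something is new, unique, unknown or untested is made for them only; others in the source may bear on it.

Measured compounds:
compound 1 `CO[C@@H](C(=O)NC1CC[C@@H](OC(=O)C2CCCCC2)CNC1=O)[C@H](O)[C@@H](O)[C@H](O)/C=C/C(C)(C)C`: 4 nM
compound 2 `CO[C@@H](C(=O)NC1CC[C@@H](OC(=O)C2CCCCCC2)CNC1=O)[C@H](O)[C@@H](O)[C@H](O)/C=C/C(C)(C)C`: 20 nM

In an in vivo functional assay on the whole organism (MDA-MB-435 cells, Homo sapiens) for antiproliferative activity (on this read-out lower numbers stand for stronger inhibition and higher numbers for weaker inhibition), compound 1 gives 4 nM, while compound 2 gives 20 nM, the higher of the two numbers, separated from compound 1 by a 5.0-fold higher number from compound 1 to compound 2 (0.70 log units; beyond the scatter). Compound 3 `CO[C@@H](C(=O)NC1CC[C@@H](OC(=O)/C=C/c2ccccc2)CNC1=O)[C@H](O)[C@@H](O)[C@H](O)/C=C/C(C)(C)C` differs from compound 2 by 2-phenylethenyl in place of cycloheptyl on a carbonyl carbon. Among the measured compounds shown here, the only step at hand, a 5.0-fold higher number from compound 1 to compound 2 (0.70 log units; beyond the scatter), concerns ring size at the same carbonyl carbon and bears only loosely on this change. Compound 3 is therefore expected to land close to compound 2, a 1.3-fold lower number from compound 2 to compound 3 (0.12 log units; within the scatter). The estimate for compound 3 in this assay is 15 nM, within 4 nM to 60 nM.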

Compound 3, half-maximal inhibitory concentration: 20 nM
Compound 3: middle estimate off by 1.3-fold (0.12 log units), on the low side; the measured number falls inside the stated range.
By their numbers in this assay, from the lowest: compound 1; then compounds 2 and 3 (each within the scatter of the next).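

In this assay the swap of cycloheptyl for 2-phenylethenyl on this carbonyl carbon gives no change at the digits printed from compound 2 to compound 3 (within the scatter) and so shows that an aromatic group can stand here on a level with a saturated seven-membered ring. Cyclohexyl still stands apart from the new group, with a 5.0-fold higher number from compound 1 to compound 3 (0.70 log units; beyond the scatter) on the same read-out, so compound 1 alone holds the low number among the three. Going by these compounds, whether cyclopentyl, a saturated 2-phenylethyl group or a chain carrying an amine would reach compound 1 stays open. Nothing on hand explains these numbers.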